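Swapping Cyano for Trifluoromethoxy on the Sulfonyl Ring

The source may report more compounds than this note shows. Statements on the series, on what has been measured and on what is new or still open speak of the compounds shown alone.

Two compounds share a core and differ only in one group on the sulfonyl-bearing aromatic ring. Compound 1 `CN1CCN(c2ccc(C3=NN(S(=O)(=O)c4ccc(C(F)(F)F)cc4)C(c4ccc(N(C)C)cc4)C3)cc2)CC1` carries a trifluoromethyl there; in a functional assay on HCC1806 cells (Homo sapiens) for inhibition, read by sulforhodamine B assay, tested at 10 uM (a lower number here means less inhibition, a higher number more inhibition at the concentration tested (going by the name of the read-out)), compound 1 gives 27%. Compound 2 `CN1CCN(c2ccc(C3=NN(S(=O)(=O)c4ccc(C#N)cc4)C(c4ccc(N(C)C)cc4)C3)cc2)CC1` carries a cyano instead, and in this assay compound 2 gives 99.8%, the highest of the two numbers. For the measured compounds named here, the single measured step, a number 72.8 percentage points higher from compound 1 to compound 2 (beyond the scatter), shows that this one exchange moved the read-out far.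

Compound 3 `CN1CCN(c2ccc(C3=NN(S(=O)(=O)c4ccc(OC(F)(F)F)cc4)C(c4ccc(N(C)C)cc4)C3)cc2)CC1` is not yet measured. It differs from compound 2 by trifluoromethoxy in place of cyano on an aromatic carbon. Going by the values given here, the only step that bears on this change is the one from compound 1 to compound 2, which was large, so a change at this same position can be expected to matter in this assay. Trifluoromethoxy shares three fluorines with the trifluoromethyl of compound 1, whose value was 27%, so a sizeable drop is expected, giving a number 59.8 percentage points lower from compound 2 to compound 3 (beyond the scatter). Compound 3 is therefore estimated at 40%, within a range from 10% to 85%.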

Compound 3, a percentage reported as inhibition, at one concentration (the size of the read-out at that concentration, not a potency): 70.8%
Compound 3: the middle estimate sits 30.8 percentage points below what was measured, and the stated range covers the measured number.
By their numbers in this assay, from the lowest: compound 1; then compound 3; then compound 2.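

In this assay, this carbon on the sulfonyl ring, para to a large group, now has three compared groups, and they fall in a clear order: trifluoromethyl gives the lowest number, trifluoromethoxy the middle one and cyano the highest. Trifluoromethoxy in place of cyano gives a number 29 percentage points lower from compound 2 to compound 3 (beyond the scatter) and so gives up only part of the read-out, while trifluoromethoxy in place of trifluoromethyl gives a number 43.8 percentage points higher from compound 1 to compound 3 (beyond the scatter) and recovers more than that loss, which shows that three fluorines on the group do not by themselves fix the number at this position. Nothing available here explains why the groups fall in this order.

Still open, on these data alone, is how quite different groups would behave on this same carbon, such as an amine, a carboxylic acid or a plain methoxy, since these three compounds cover only a narrow set of substituents. Also open, as far as these compounds go, is whether the same order would hold at other concentrations or in other cell lines, given that a single-concentration read-out shows the size of an effect and not a potency.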